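The source may report more compounds than this note shows. Statements on the series, on what has been measured and on what is new or still open speak of the compounds shown alone.

Compound 1 `COc1ccc(-c2cn3ccnc(N)c3n2)cc1` gives 1% in an assay on cells for displacement of a labelled ligand from adenosine receptor A1 (Homo sapiens), read by scintillation counting, with a stated time of 120 min, tested at 1 uM; a higher number here means more inhibition at the concentration tested (going by the name of the read-out), a lower number less inhibition.
Compound 2 `COc1ccc(-c2cn3ccnc(NC(=O)c4ccccc4)c3n2)cc1` gives 1% in this assay.

In this assay compound 1 stands level with compound 2 at the digits shown, and the one step measured, no change at the digits printed from compound 1 to compound 2 (within the scatter), brought no change within the scatter when a benzoyl took the place of a hydrogen on a nitrogen on an aromatic ring. Compound 3 `COc1ccc(-c2cn3cc(Br)nc(N)c3n2)cc1` has not yet been measured in this assay. It differs from compound 1 in one place: bromo in place of hydrogen on an aromatic carbon. Among the compounds with values here, no measured step bears directly on this change; the only step available, no change at the digits printed from compound 1 to compound 2 (within the scatter), concerns a different part of the core and a much larger group, and it showed nothing beyond the scatter. With nothing to suggest movement, the expectation for compound 3 in this assay is a step of a number 5 percentage points higher from compound 1 to compound 3 (within the scatter), that is, none beyond the scatter. Compound 3 is therefore estimated at 6%, with a range from -5% to 25%.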

Compound 3, a percentage reported as inhibition, at one concentration (the size of the read-out at that concentration, not a potency): 29%
Beside the measured number, compound 3's estimate is 23 percentage points below it; the whole stated range lies below it.
By their numbers in this assay, from the lowest: compounds 1 and 2 (each within the scatter of the next); then compound 3.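

In this assay, this position turns out to respond to substitution: bromo in place of hydrogen on an aromatic carbon, next to the ring nitrogen, gives a number 28 percentage points higher from compound 1 to compound 3 (beyond the scatter). The only earlier step, the much larger benzoyl on the nitrogen, gave no change at the digits printed from compound 1 to compound 2 (within the scatter), so this is the first change shown to move the read-out on the shared core. Nothing given here explains why the bromo has this effect.

Going by these compounds, it remains open whether chloro, methyl or an amine on the same carbon would move the read-out as bromo does, and whether bromo would still count with benzoyl on the nitrogen. On these data alone, compound 3 at 29% is also a reading at one concentration, so its potency remains unknown.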